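A few compounds are considered here, and "the series" means these few. Any claim that something is new, unique, unknown or untested is made for them only; others in the source may bear on it.

Of the compounds shown here, three have been measured in a functional assay on CHO-K1 cells for antagonist activity at C-X-C chemokine receptor type 3 (Homo sapiens), read by FLIPR, with a stated time of 10 min, in the presence of a further agent that is not named here (on this read-out lower numbers stand for stronger inhibition and higher numbers for weaker inhibition), so far. Compound 1 `COC1CCN(CC(=O)N2CCN(c3sc(C(F)(F)F)nc3-c3nc4ccccc4[nH]3)C[C@H]2C)C1` gives 42 nM, the highest of the three numbers, which here means the weakest inhibition. Compound 2 `Cc1nc(C)n(CC(=O)N2CCN(c3sc(C(F)(F)F)nc3-c3nc4c(F)cccc4[nH]3)C[C@H]2C)n1` gives 3.1 nM, and compound 3 `Cc1nc(C)n(CC(=O)N2CCN(c3sc(C(F)(F)F)nc3-c3nc4ccc(C(C)(C)O)c(F)c4[nH]3)C[C@H]2C)n1` gives 9.4 nM; both differ from compound 1 in more than one place, so no single structural step can be read from them, and the gaps to compound 1 lie beyond the usual scatter of this assay.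

Compound 4 `C[C@@H]1CN(c2sc(C(F)(F)F)nc2-c2nc3ccccc3[nH]2)CCN1C(=O)Cn1cc(Cl)cn1` has not yet been measured. It differs from compound 1 by one change: 4-chloro-1H-pyrazol-1-yl in place of 3-methoxypyrrolidin-1-yl on a saturated chain carbon bound to a carbonyl carbon. The amide carbonyl and the rest of the shared core stay exactly as in compound 1.

Among the measured compounds shown here, with no matched pair to lean on, the expected direction rests only on the fact that compounds 2 and 3, which carry another group on the same chain carbon, sit well below compound 1: compound 2 at 3.1 nM and compound 3 at 9.4 nM. On that basis a moderate step toward lower numbers, beyond the scatter, is expected for the move from compound 1 to compound 4, a 3.0-fold lower number from compound 1 to compound 4 (0.48 log units; beyond the scatter). Compound 4 is therefore estimated at 14 nM in this assay, within a range of 5 nM to 40 nM.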

Compound 4, half-maximal inhibitory concentration: 1.7 nM
Beside the measured number, compound 4's estimate is 8.2-fold (0.92 log units) above it; measured number outside the range, below it.
By their numbers in this assay, from the lowest: compounds 4 and 2 (each within the scatter of the next); then compound 3; then compound 1.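

In this assay the change from 3-methoxypyrrolidin-1-yl to 4-chloro-1H-pyrazol-1-yl, on a saturated chain carbon bound to a carbonyl carbon, reads as a 25-fold lower number from compound 1 to compound 4 (1.39 log units; beyond the scatter) and counts as a large step. Among the compounds shown here, this is the first step that can be read at one place, with the amide carbonyl and the shared core held the same, so it shows that this position alone can move the number this far. The swap replaces a non-aromatic ring with an aromatic ring and keeps the listed counts of hydrogen-bond donors and acceptors unchanged, but no measurement here explains the drop.

The step changes several things at once, so the compounds shown do not separate the part played by the chlorine from that of the aromatic ring with its 2 hetero atoms. A plain 1H-pyrazol-1-yl group, with hydrogen in place of the chlorine, or a 4-bromo-1H-pyrazol-1-yl group on the same chain carbon, would be needed to pull those parts apart.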